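Amino for Nitro: an Unreadable Step Repeated

This account rests on a few compounds, and the source may have more. Where it says the series, first, only, none or still open, it means among the compounds named here.

Compound 1 `COC(=O)c1c(-c2ccc([N+](=O)[O-])cc2)oc2ccccc2c1=O` and compound 2 `COC(=O)c1c(-c2ccc(N)cc2)oc2ccccc2c1=O` share one core and differ by amino in place of nitro on an aromatic carbon. In a functional assay on MCF7 cells (Homo sapiens) for cytotoxicity, read by MTT assay, with a stated time of 6 days (a lower number here means that less compound is needed, a higher number that more compound is needed for the effect), compound 1 gives only a limit, > 25 ug/mL. In this assay compound 2 likewise gives only a limit, > 25 ug/mL. The step that the two limits leave unreadable from compound 1 to compound 2 therefore cannot be read. Compound 3 `O=c1cc(-c2ccc([N+](=O)[O-])cc2)oc2cc(O)ccc12` carries a different core; how the two cores differ is not broken down here. In this assay compound 3 also gives only a limit, > 25 ug/mL. Compound 4 `Nc1ccc(-c2cc(=O)c3ccc(O)cc3o2)cc1`, not yet measured, differs from compound 3 by amino in place of nitro on an aromatic carbon, the same change as between compound 1 and compound 2. Among the measured compounds shown here, because of the limit of > 25 ug/mL in this assay, at which 3 of the 3 values shown sit, no measured step sets a size for this change. The expected step that the limit leaves unreadable from compound 3 to compound 4 rests only on that shared limit. Compound 4 is estimated at 35 ug/mL, within 10 ug/mL to 120 ug/mL, most likely again only a limit.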

Compound 4, concentration for half-maximal effect: > 25 ug/mL
Compound 4: no number, only a limit; the forecaster's own chance of this, stated with the estimate: 70%; the middle value lies beyond the limit too.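

Among the compounds shown here, compound 3 and compound 4 each give only a limit, so no step between them can be read: the limit of > 25 ug/mL in this assay, at which 4 of the 4 values shown sit. The compounds shown leave open what size amino in place of nitro has on either core.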